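The compounds below may be only part of what the source reports. "The series", "measured", "known", "first", "only" and "open" are said of these compounds alone.

Compound 1 `COC(=O)c1ccc(NCc2cncn2Cc2ccc(Cl)cc2)cc1-c1ccccc1`: 25000 nM
Compound 2 `CC(=O)c1ccc(NCc2cncn2Cc2ccc(-c3ccccc3)cc2)cc1-c1ccccc1`: > 10000 nM
Compound 3 `O=C(OC1CCCCC1)c1ccc(NCc2cncn2Cc2ccc(-c3ccccc3)cc2)cc1-c1ccccc1`: > 10000 nM

Among the measured compounds shown here, in a toxicity assay on NIH3T3 cells (Mus musculus) for cytotoxicity, read by resazurin assay (a lower number here means that less compound is needed, a higher number that more compound is needed for the effect), compound 1 gives 25000 nM, the only number among the three values shown. For compound 2 the value > 10000 nM is a limit of the assay. For compound 3 the value > 10000 nM is likewise a limit. The step that the two limits leave unreadable from compound 2 to compound 3 cannot be read because both of its ends sit at the limit of > 10000 nM in this assay, at which 2 of the 3 values shown sit.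

Compound 4 `COC(=O)c1ccc(NCc2cncn2Cc2cccc(Cl)c2)cc1-c1ccccc1` differs from compound 1 by 3-chlorophenyl in place of 4-chlorophenyl on a saturated chain carbon bound to an aromatic nitrogen. No measured step involves this change, and the one step shown is unreadable, so nothing among the measurements points in a direction. The expected step is therefore no change at the digits printed from compound 1 to compound 4 (within the scatter), within the scatter. Compound 4 is estimated to give 25000 nM in this assay, with a range from 10000 nM to 60000 nM.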

Compound 4, half-maximal effective concentration: > 10000 nM
Compound 4 was reported as a limit (the forecaster's own chance of this, stated with the estimate: 35%); the middle value is on the limit's open side.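

In this assay compound 4 gives > 10000 nM, which is a limit, so no step between compound 1 and compound 4 can be read: the limit of > 10000 nM in this assay, at which 3 of the 4 values shown sit.

The compounds shown leave open whether 3-chlorophenyl in place of 4-chlorophenyl changes the concentration needed in this assay at all.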